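Side-chain end group changes in the cholesterol transporter series

A few compounds are considered here, and "the series" means these few. Any claim that something is new, unique, unknown or untested is made for them only; others in the source may bear on it.

Measured: compound 1 `O=C(CN1CN(c2ccccc2)C2(CCN(C(=O)c3ccc(C4CCCCC4)cc3)CC2)C1=O)NCCO`, 2000 nM; compound 2 `CC(C)(C)OC(=O)NCCCCNC(=O)CN1CN(c2ccccc2)C2(CCN(C(=O)c3ccc(C4CCCCC4)cc3)CC2)C1=O`, 4600 nM.

In an assay on HEK293 cells for displacement of a labelled ligand from NPC1-like intracellular cholesterol transporter 1 (Homo sapiens) (a higher number here means a weaker inhibitor, a lower number a stronger inhibitor), compound 2 gives 4600 nM, the higher of the two numbers; compound 1 gives 2000 nM. Within the data shown here, the single measured step, a 2.3-fold higher number from compound 1 to compound 2 (0.36 log units; beyond the scatter), came with 2-((tert-butoxycarbonyl)amino)ethyl entering in place of hydroxy. Compound 3 `CS(=O)(=O)NCCNC(=O)CN1CN(c2ccccc2)C2(CCN(C(=O)c3ccc(C4CCCCC4)cc3)CC2)C1=O` carries methanesulfonamido in place of 2-((tert-butoxycarbonyl)amino)ethyl on a saturated chain carbon, two bonds along the chain from an amide-type nitrogen. Among the measured compounds shown here, this removes the group whose arrival accompanied the modest rise from compound 1 to compound 2, so a partial return toward the number of compound 1 is the only guide available. Compound 3 is expected to give 2800 nM (range 1200 nM to 6500 nM), estimated as a 1.6-fold lower number from compound 2 to compound 3 (0.22 log units; within the scatter).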

Compound 3, half-maximal inhibitory concentration: 2100 nM
Compound 3: the middle estimate sits 1.3-fold (0.12 log units) above what was measured; the range from low to high includes it.
By their numbers in this assay, from the lowest: compounds 1 and 3 (each within the scatter of the next); then compound 2.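

In this assay, the change to methanesulfonamido gives a 2.2-fold lower number from compound 2 to compound 3 (0.34 log units; beyond the scatter), so the rise seen with 2-((tert-butoxycarbonyl)amino)ethyl does not carry over to every group at this place. Set against hydroxy, methanesulfonamido gives a 1.1-fold higher number from compound 1 to compound 3 (0.02 log units; within the scatter), so these two end groups are not told apart here. No data on hand explain either step.

The step from compound 2 changes chain and end group together, so 4-(methanesulfonamido)butyl would be needed to separate them. As far as these compounds go, how a free amine or a carboxylic acid at the chain end compares remains open.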